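Swapping a Piperidine Side Chain in an Antiproliferative Series

The source may hold more compounds than are shown below. What is called first, only, known or untested is meant among the compounds shown, and "the series" means these compounds.

In a functional assay on MCF7 cells (Homo sapiens) for antiproliferative activity (on this read-out lower numbers stand for stronger inhibition and higher numbers for weaker inhibition), compound 1 (`CC(=O)Oc1ccc(C(=O)Nc2cc3ccc(OCC4CCCN(C)C4)c(C)c3oc2=O)cc1CC=C(C)C`) gives 1650 nM and compound 2 (`CC(C)=CCc1cc(C(=O)Nc2cc3ccc(OCCC4CCCCN4)c(C)c3oc2=O)ccc1O`) gives 710 nM as the lower of the two numbers, a gap beyond the usual scatter. Compound 3 (`CC(C)=CCc1cc(C(=O)Nc2cc3ccc(OCC4CCCN(C)C4)c(C)c3oc2=O)ccc1O`) is still unmeasured. Its structure differs from that of compound 2 as follows (1-methylpiperidin-3-yl in place of (piperidin-2-yl)methyl on a saturated chain carbon bound to an oxygen on an aromatic ring), with 1-methylpiperidin-3-yl in place of (piperidin-2-yl)methyl on a saturated chain carbon bound to an oxygen on an aromatic ring. Going by the values given here, no step between measured compounds bears directly on this change, so only a small shift is expected in this assay and it is expected to stay within the scatter. Among the compounds with values here, the tentative direction is towards a higher number, as the only other measured compound, compound 1, stands at 1650 nM on that side. The expected change is a 1.4-fold higher number from compound 2 to compound 3 (0.15 log units; within the scatter) in this estimate. For compound 3 the estimated value is 1000 nM (expected range 400 nM to 2500 nM).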

Compound 3, half-maximal inhibitory concentration: 2640 nM
Beside the measured number, compound 3's estimate is 2.6-fold (0.42 log units) below it; measured number outside the range, above it.
By their numbers in this assay, from the lowest: compound 2; then compounds 1 and 3 (each within the scatter of the next).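

In this assay, the position on a saturated chain carbon bound to an oxygen on an aromatic ring proves sensitive to how the same atoms are joined: 1-methylpiperidin-3-yl in place of (piperidin-2-yl)methyl gives a 3.7-fold higher number from compound 2 to compound 3 (0.57 log units; beyond the scatter). Hydrogen in place of acetyl on an oxygen on an aromatic ring gives a 1.6-fold higher number from compound 1 to compound 3 (0.20 log units; within the scatter), so with this side chain held constant, the two compounds stay within the scatter of each other. Nothing available explains the side-chain step.

The step combines a methyl group on the ring nitrogen with a different ring attachment and chain, and the compounds shown do not separate these changes. A 2-(1-methylpiperidin-2-yl)ethyl or an unmethylated (piperidin-3-yl)methyl group would help tell them apart.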